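The source may hold more compounds than are shown below. What is called first, only, known or untested is meant among the compounds shown, and "the series" means these compounds.

In a functional assay on MIA PaCa-2 cells (Homo sapiens) for inhibition, read by MTT assay, with a stated time of 72 h (a higher number here means a weaker inhibitor, a lower number a stronger inhibitor), compound 1 (`COc1cc(NC(C)CCCNC(=O)Nc2ccc(Br)cc2)c2ncccc2c1`) gives 23000 nM and compound 2 (`COc1cc(NC(C)CCCNC(=O)Nc2ccc(F)cc2)c2ncccc2c1`) gives 21000 nM on the same scale. Compound 3 (`COc1cc(NC(C)CCCNC(=O)NNC(=O)Nc2ccc(Br)cc2)c2ncccc2c1`) gives 231000 nM as the highest number of the three, which makes it the weakest inhibitor measured so far. The unmeasured compound 4 (`COc1cc(NC(C)CCCNC(=O)Nc2cccc(C(F)(F)F)c2)c2ncccc2c1`) differs from compound 3 by one change (3-(trifluoromethyl)phenyl in place of ((4-bromophenyl)carbamoyl)amino on an amide-type nitrogen): 3-(trifluoromethyl)phenyl replaces ((4-bromophenyl)carbamoyl)amino on an amide-type nitrogen. That nitrogen then carries a phenyl ring, as it does in compound 1 and compound 2.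

Two measured steps, a 10-fold higher number from compound 1 to compound 3 (1.00 log units; beyond the scatter) and an 11-fold higher number from compound 2 to compound 3 (1.04 log units; beyond the scatter), bear most directly on this. Both lie beyond the scatter, so reversing that kind of change leads to the expectation of a drop of similar size in this assay toward a lower number. The swap of halogen on the ring gives a 1.1-fold lower number from compound 1 to compound 2 (0.04 log units; within the scatter) and stays within the scatter, which hints that the group on the ring may matter little. Within the data shown here, no measured compound carries a trifluoromethyl group, however, so the range has to stay wide. The step expected is a 12-fold lower number from compound 3 to compound 4 (1.06 log units; beyond the scatter) by this estimate. Compound 4 is estimated at 20000 nM with a likely range from 9000 nM to 45000 nM in this expectation.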

Compound 4, half-maximal inhibitory concentration: 17000 nM
Compound 4: the middle estimate sits 1.2-fold (0.07 log units) above what was measured; measured number inside the range.
By their numbers in this assay, from the lowest: compounds 4, 2 and 1 (each within the scatter of the next); then compound 3.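

In this assay, putting 3-(trifluoromethyl)phenyl in place of ((4-bromophenyl)carbamoyl)amino on the amide-type nitrogen gives a 14-fold lower number from compound 3 to compound 4 (1.13 log units; beyond the scatter) and so brings a third phenyl ring on that nitrogen into the comparison, this one bearing a trifluoromethyl group instead of a halogen. The new ring cannot be told apart from the two earlier ones: the readings are a 1.2-fold lower number from compound 2 to compound 4 (0.09 log units; within the scatter) and a 1.4-fold lower number from compound 1 to compound 4 (0.13 log units; within the scatter) and show that, among the three compounds with a phenyl ring on that nitrogen, the step from a single halogen to trifluoromethyl leaves the number within the usual scatter, while compound 3 remains the only one that stands apart. Nothing measured here explains these numbers.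

The compounds shown leave open whether a phenyl ring carrying an amine or a carboxylic acid, or a longer chain on that nitrogen, would move the number beyond the scatter of these three. They also leave open whether the high number of compound 3 follows the extra carbamoyl-amino link itself, since that link appears with only a 4-bromophenyl ring at its end.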